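A few compounds are considered here, and "the series" means these few. Any claim that something is new, unique, unknown or untested is made for them only; others in the source may bear on it.

Three related compounds have been measured in an ADME assay on L6 cells (Rattus norvegicus) for cytotoxicity; on this read-out higher numbers stand for weaker inhibition and lower numbers for stronger inhibition. Compound 1 (`CN1CCN(CCC(=O)N2CCC3(N4CCN(C)CC4)CC(c4ccccc4)C2C(c2ccccc2)C3)CC1`) gives 161000 nM, compound 2 (`CN1CCN(CCC(=O)NC2CC3(N4CCN(C)CC4)CC(c4ccccc4)C2C(c2ccccc2)C3)CC1`) gives 67900 nM, and compound 3 (`CN1CCN(CCCN2CCC3(N4CCN(C)CC4)CC(c4ccccc4)C2C(c2ccccc2)C3)CC1`) gives 47800 nM. Compound 3 lies within the usual scatter of compound 2, while its number is clearly lower than that of compound 1.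

Compound 4 (`CN1CCN(CCCN2CCC3(N4CCCC4)CC(c4ccccc4)C2C(c2ccccc2)C3)CC1`) keeps the side chain of compound 3 but carries pyrrolidin-1-yl in place of 4-methylpiperazin-1-yl on a saturated ring carbon.

Among the compounds with values here, only one measured step offers any guide, and it changes a different place, an amine nitrogen in a ring. That step, a 3.4-fold lower number from compound 1 to compound 3 (0.53 log units; beyond the scatter), is modest. Within the data shown here, no measured pair tests the new swap directly, so the step can lend only a rough size, and the direction is a cautious judgement. In this assay, a step no larger than that one is expected, leaning towards a lower number: a 1.7-fold lower number from compound 3 to compound 4 (0.23 log units; within the scatter). For compound 4 the estimated value is 28000 nM, within an expected range of 9000 nM to 80000 nM.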

Compound 4, half-maximal inhibitory concentration: 27500 nM
Estimate against measurement, compound 4: 1.0-fold (0.01 log units) above; the range from low to high includes it.
By their numbers in this assay, from the lowest: compounds 4, 3 and 2 (each within the scatter of the next, the first and the last beyond it); then compound 1.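

Within the data shown here, this is the first look at the saturated ring carbon of the core; the earlier step changed only the side chain on the ring nitrogen. In this assay, replacing 4-methylpiperazin-1-yl (7 heavy atoms, 2 nitrogen) with pyrrolidin-1-yl (5 heavy atoms, 1 nitrogen) gives a 1.7-fold lower number from compound 3 to compound 4 (0.24 log units; within the scatter), so this read-out does not separate the two groups, and the second ring nitrogen with its methyl group can be lost here without a change beyond the scatter. No available evidence offers an explanation for this result.

On these data alone, whether a piperidin-1-yl ring, a morpholin-4-yl ring or an open-chain dimethylamino group on this carbon would fall within the same scatter remains open. As far as these compounds go, it is also open whether the same swap would give a similar step with the carbonyl side chain of compound 1.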